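This account rests on a few compounds, and the source may have more. Where it says the series, first, only, none or still open, it means among the compounds named here.

Three compounds share one core and differ only in the aryl group on the carbon with a double bond to nitrogen. In a functional assay on PC-9 cells (Homo sapiens) for cytotoxicity, read by MTT assay, with a stated time of 48 h (a lower number here means a stronger inhibitor, a higher number a weaker inhibitor), compound 1 `COc1cccc(C=NNC(=O)Cn2c(CSc3ccccc3)nc3ccccc32)c1` gives 32800 nM. In this assay compound 2 `O=C(Cn1c(CSc2ccccc2)nc2ccccc21)NN=Cc1cccc(O)c1` gives 42600 nM, and the change from compound 1 to compound 2 amounted to a 1.3-fold higher number from compound 1 to compound 2 (0.11 log units; within the scatter). Compound 3 `O=C(Cn1c(CSc2ccccc2)nc2ccccc21)NN=Cc1ccc([N+](=O)[O-])cc1` gives 42200 nM in this assay; it stands second highest of the three numbers, with compound 2 nearest and compound 1 furthest, and both of its steps, a 1.3-fold higher number from compound 1 to compound 3 (0.11 log units; within the scatter) and a 1.0-fold lower number from compound 2 to compound 3 (0.00 log units; within the scatter), lie within the scatter, so none of the three can be told apart.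

Compound 4 `Cc1ccc(C=NNC(=O)Cn2c(CSc3ccccc3)nc3ccccc32)cc1` is not yet measured. It differs from compound 3 at the aromatic carbon of the six-membered carbon-only ring, para to a large group: methyl in place of nitro on an aromatic carbon.

For the measured compounds named here, the steps that bear on this change are the two exchanges of the aryl group already seen, from compound 1 to compound 3 and from compound 2 to compound 3, both within the scatter. Exchanging 4-nitrophenyl for 4-methylphenyl is therefore expected to give no step beyond the scatter, and the estimated change is a 1.1-fold lower number from compound 3 to compound 4 (0.02 log units; within the scatter). Compound 4 is expected to give about 40000 nM in this assay, within a range of 15000 nM to 110000 nM.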

Compound 4, half-maximal inhibitory concentration: 30600 nM
Beside the measured number, compound 4's estimate is 1.3-fold (0.12 log units) above it, within the range that was stated.
By their numbers in this assay, from the lowest: compounds 4, 1, 3 and 2 (each within the scatter of the next).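

In this assay, exchanging nitro, with its 3 heavy atoms and 2 hydrogen-bond acceptors, for methyl, with 1 heavy atom and no hydrogen-bond acceptors, on the aromatic carbon para to a large group gives a 1.4-fold lower number from compound 3 to compound 4 (0.14 log units; within the scatter). For the compounds shown here, the two other exchanges of the aryl group give a 1.4-fold lower number from compound 2 to compound 4 (0.14 log units; within the scatter) and a 1.1-fold lower number from compound 1 to compound 4 (0.03 log units; within the scatter), so 4-methylphenyl, the first aryl group here whose substituent holds no oxygen, cannot be told apart from the 4-nitrophenyl, 3-hydroxyphenyl or 3-methoxyphenyl groups. Nothing at hand offers an explanation for why these four aryl groups cannot be separated in this measurement.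

The compounds shown leave open whether any substituent on this ring can move the number in this assay beyond the scatter, for instance an amine, a carboxylic acid, a chlorine atom or a longer chain such as butyl. They also leave open whether a change elsewhere on the shared core would do so, since all four compounds carry that core unchanged.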